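This account rests on a few compounds, and the source may have more. Where it says the series, first, only, none or still open, it means among the compounds named here.

Measured compounds:
- compound 1, `NS(=O)(=O)CC(=O)NCCSc1nonc1/C(=N/O)Nc1cccc(C(F)F)c1`, 17 nM in an assay for inhibition of Indoleamine 2,3-dioxygenase 1 (Homo sapiens), read by fluorescence, with a stated time of 24 h; on this read-out higher numbers stand for weaker inhibition and lower numbers for stronger inhibition
- compound 2, `C[C@H](CSc1nonc1/C(=N/O)Nc1ccc(F)c(Br)c1)NC(=O)CS(N)(=O)=O`, 12 nM in this assay
- compound 3, `NS(=O)(=O)NCCSc1nonc1/C(=N/O)Nc1ccc(F)c(Br)c1`, 2.8 nM in this assay

Compound 1 gives the highest number of the three in this assay. Its nearest neighbour is compound 2, whose value lies within the scatter of that of compound 1, so the two cannot be told apart. Compound 3 sits further off, with a number low enough to lie beyond the scatter; none of these pairs differs in only one place, so no single change can be credited for that gap.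

Compound 4, `N#Cc1cccc(N/C(=N\O)c2nonc2SCCNC(=O)CS(N)(=O)=O)c1`, has not yet been measured. It differs from compound 1 in one place: cyano in place of difluoromethyl on an aromatic carbon. Among the measured compounds shown here, no measured pair shows this change, so there is nothing to copy from. The shared core and the chain carrying the sulfonamide stay as they are in compound 1. The step from compound 1 to compound 4 is expected to be small, a 1.5-fold higher number from compound 1 to compound 4 (0.17 log units; within the scatter), with no clear direction beyond the scatter. For compound 4 the estimate in this assay is 25 nM, with a likely range from 8 nM to 75 nM.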

Compound 4, half-maximal inhibitory concentration: 44 nM
The estimate for compound 4 lay 1.8-fold (0.25 log units) below the measured number; the measured number falls inside the stated range.
By their numbers in this assay, from the lowest: compound 3; then compounds 2 and 1 (each within the scatter of the next); then compound 4.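

With the shared core and the chain carrying the sulfonamide held constant, cyano in place of difluoromethyl on an aromatic carbon gives a 2.6-fold higher number from compound 1 to compound 4 (0.41 log units; beyond the scatter) in this assay. Among the compounds shown here, this is the first step here that differs in one place, and it shows that the group at this position affects the read-out: inhibition is modestly weaker with cyano, by a margin beyond the usual scatter. Nothing measured for these compounds accounts for the direction of this step.

Going by these compounds, whether the same change would have a similar effect on the ring or the chain of compound 3 remains open. So does how a trifluoromethyl group, a chlorine atom or a methoxy group at this position would compare with difluoromethyl and cyano.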